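Nitro addition on a second sulfonamide core

The source may report more compounds than this note shows. Statements on the series, on what has been measured and on what is new or still open speak of the compounds shown alone.

The measured compounds:
compound 1, `COc1cc(NC(=O)c2ccc(Cl)cc2)ccc1NS(=O)(=O)C(F)(F)F`, > 250000 nM in an ADME assay on HEK293 cells (Homo sapiens) for cytotoxicity, read by MTT assay, with a stated time of 48 h; on this read-out higher numbers stand for weaker inhibition and lower numbers for stronger inhibition
compound 2, `COc1cc(NC(=O)c2ccc(Cl)c([N+](=O)[O-])c2)ccc1NS(=O)(=O)C(F)(F)F`, > 250000 nM
compound 3, `CS(=O)(=O)Nc1ccc(NC(=O)c2ccc(Cl)cc2)cc1Cl`, 167000 nM

Compound 1 gives only a limit of this assay, not a number. Compound 2 likewise gives only a limit, not a number. Compound 3 is the only one of the three with a read number. The change from compound 1 to compound 2 is nitro in place of hydrogen on an aromatic carbon, and its step, a step that the two limits leave unreadable from compound 1 to compound 2, cannot be read because of the limit of > 250000 nM in this assay, at which 2 of the 3 values shown sit, at which both values sit.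

The difference between the core of compound 1 and the core of compound 3 is not broken down here. Compound 4, `CS(=O)(=O)Nc1ccc(NC(=O)c2ccc(Cl)c([N+](=O)[O-])c2)cc1Cl`, is not yet measured; it differs from compound 3 by nitro in place of hydrogen on an aromatic carbon, the same change made from compound 1 to compound 2, at a place described in the same words.

For the measured compounds named here, since the earlier step is unreadable, the expectation for compound 4 rests on compound 3 alone, whose value 167000 nM is the only read number. The expected step is a 1.0-fold higher number from compound 3 to compound 4 (0.01 log units; within the scatter), that is, close to no change. Compound 4 is therefore estimated at 170000 nM, between 60000 nM and 300000 nM.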

Compound 4, half-maximal inhibitory concentration: 204000 nM
The estimate for compound 4 lay 1.2-fold (0.08 log units) below the measured number; measured number inside the range.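

In this assay, nitro in place of hydrogen on an aromatic carbon gives a 1.2-fold higher number from compound 3 to compound 4 (0.09 log units; within the scatter), a step no larger than repeated measurements of this kind would show by themselves. For the compounds shown here, the matching step on the core of compound 1 cannot be read, because compound 1 and compound 2 each give only a limit, so the two cores offer no pair of steps to set side by side: the limit of > 250000 nM in this assay, at which 2 of the 4 values shown sit. Going by these compounds alone, the one readable step therefore describes the core of compound 3 alone, and it neither supports nor contradicts the idea that this change behaves alike on both cores.

The compounds shown leave open whether a different group in place of the same hydrogen, such as an amine or a carboxylic acid, would give a step beyond the scatter on the core of compound 3. They also leave open how nitro would behave on a further core where both partners of the pair give read numbers.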